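The source may report more compounds than this note shows. Statements on the series, on what has been measured and on what is new or still open speak of the compounds shown alone.

Within the data shown here, compound 1 `Cn1ccc(-c2ccc(Cn3cc(C(=O)N[C@H]4CCOC[C@@H]4O)c4ncccc43)cc2)n1` is one of two compounds measured in an ADME assay on liver for metabolic stability, with Liver microsome (Homo sapiens) as the target, using microsomes (on this read-out higher numbers stand for fast clearance and lower numbers for slow clearance), and on that read-out compound 1 gives 10.6 mL/min/kg. Among the measured compounds shown here, the only other measured compound is compound 2 `O=C(N[C@H]1CCOC[C@@H]1O)c1cn(Cc2ccc(-c3cc[nH]n3)cc2)c2cccnc12`, which in this assay gives 9.2 mL/min/kg; the step of a 1.2-fold lower number from compound 1 to compound 2 (0.06 log units; within the scatter) is the whole of what has been seen so far, so compound 1 stands alongside compound 2 with no difference between them that the measurement can resolve.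

Compound 3 `Cc1ccnc2c(C(=O)N[C@H]3CCOC[C@@H]3O)cn(Cc3ccc(-c4ccn(C)n4)cc3)c12` is not yet measured. It differs from compound 1 by methyl in place of hydrogen on an aromatic carbon. For the measured compounds named here, the one measured step, from compound 1 to compound 2, concerns a different place in the molecule and was within the scatter, so it offers no direct precedent for adding a methyl on the six-membered ring of the core. With nothing in the measured compounds pointing toward a larger or smaller number, the expectation for compound 3 is a step of a 1.1-fold higher number from compound 1 to compound 3 (0.05 log units; within the scatter), that is, no change beyond the scatter in this assay. The estimate for compound 3 in this assay is therefore 12 mL/min/kg, with a range from 6 mL/min/kg to 24 mL/min/kg.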

Compound 3, clearance: 10.6 mL/min/kg
Compound 3: middle estimate off by 1.1-fold (0.05 log units), on the high side; the measured number falls inside the stated range.
By their numbers in this assay, from the lowest: compounds 2, 1 and 3 (each within the scatter of the next).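

In this assay, placing methyl in place of hydrogen on an aromatic carbon of the six-membered aromatic ring with 1 nitrogen, opposite the ring nitrogen, gives no change at the digits printed from compound 1 to compound 3 (within the scatter). Among these compounds, this is the first reading at this position on the shared core, since the earlier step between measured compounds concerned an aromatic nitrogen elsewhere in the molecule, and it shows that this one added carbon leaves no difference in clearance that the measurement can resolve. No supporting data bear on the reason for this outcome, so the result stands as an observation only.

Among the compounds shown here, a methyl is only one small group, so it remains open whether a longer chain such as ethyl, an amine, a carboxylic acid or a chlorine atom at the same position would also leave the clearance within the scatter. From the compounds shown here alone, it also remains open whether this methyl would behave the same way in compound 2, which carries hydrogen rather than methyl on the aromatic nitrogen.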